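This account rests on a few compounds, and the source may have more. Where it says the series, first, only, none or still open, it means among the compounds named here.

Working notes on the series.

Compound 1 `COc1ccc(/C=C(/Sc2ccc(Br)cc2)C(=O)c2ccc(Br)cc2)cc1` and compound 2 `O=C(/C(=C\c1ccc(OC(F)(F)F)cc1)Sc1ccc(Br)cc1)c1ccc(Br)cc1` share a core and differ only on the oxygen of the aromatic ring. In a functional assay on DU-145 cells (Homo sapiens) for inhibition, read by trypan blue exclusion, with a stated time of 96 h (a lower number here means a stronger inhibitor of growth, a higher number a weaker inhibitor of growth), compound 1 gives 25000 nM, the highest of the two numbers recorded so far. Compound 2 gives 10000 nM in this assay, and the step from compound 1 to compound 2 is a 2.5-fold lower number from compound 1 to compound 2 (0.40 log units; beyond the scatter), arising from trifluoromethyl in place of methyl on an oxygen on an aromatic ring.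

Compound 3 `O=C(/C(=C\c1ccc(F)cc1Cl)Sc1ccc(Br)cc1)c1ccc(Br)cc1` is not yet measured. Its change from compound 1 is 2-chloro-4-fluorophenyl in place of 4-methoxyphenyl on a double-bonded chain carbon bound to a double-bonded chain carbon. For the measured compounds named here, only the step from compound 1 to compound 2 bears on it, and only loosely, since there the oxygen stayed in place while here the whole 4-methoxyphenyl is exchanged. That step was modest, so a modest step is expected, most likely toward a lower number, a 1.7-fold lower number from compound 1 to compound 3 (0.22 log units; within the scatter). Compound 3 is therefore estimated at 15000 nM in this assay, within a range from 5000 nM to 50000 nM.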

Compound 3, concentration for 50% growth inhibition: 1000 nM
For compound 3 the middle estimate is 15-fold (1.18 log units) above the measured one, outside the stated range (below it).
By their numbers in this assay, from the lowest: compound 3; then compound 2; then compound 1.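

In this assay, the change to 2-chloro-4-fluorophenyl on a double-bonded chain carbon bound to a double-bonded chain carbon gives a 25-fold lower number from compound 1 to compound 3 (1.40 log units; beyond the scatter) and so reaches much further than the change on the oxygen, which gave a 2.5-fold lower number from compound 1 to compound 2 (0.40 log units; beyond the scatter) in the same assay. The whole aromatic group at this position is therefore a far stronger lever on the number than the group on its oxygen, at least for these compounds. Chlorine and fluorine enter together as the oxygen leaves, so the step cannot be assigned to any one of these atoms, and nothing measured here explains it.

Going by these compounds, it remains open whether 2-chlorophenyl or 4-fluorophenyl alone would give a step of this size. Also open, on these data alone, is how an amine or a carboxylic acid on this aromatic ring would read.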